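Para-substituent swaps in a triazole-linked series: working notes

The source may hold more compounds than are shown below. What is called first, only, known or untested is meant among the compounds shown, and "the series" means these compounds.

Measured so far in a functional assay on MCF7 cells (Homo sapiens) for antiproliferative activity, read by MTT assay, with a stated time of 48 h; a higher number here means a weaker inhibitor, a lower number a stronger inhibitor:
compound 1, `COc1cc(/C=C/C(C)=O)ccc1OCc1cn(-c2ccc(/N=N/c3ccccc3)cc2)nn1`, 75900 nM
compound 2, `COc1cc(/C=C/C(C)=O)ccc1OCc1cn(-c2ccc(NC(=O)c3ccccc3)cc2)nn1`, 86700 nM
compound 3, `COc1cc(/C=C/C(C)=O)ccc1OCc1cn(-c2ccc(C(F)(F)F)c(C(F)(F)F)c2)nn1`, 87400 nM

All three numbers fall within the usual scatter of one another, so compound 2 cannot be set apart from compound 1 or from compound 3 on the data shown; the whole set sits at weak inhibition in this assay. Among the measured compounds shown here, the one single-site step available, a 1.1-fold higher number from compound 1 to compound 2 (0.06 log units; within the scatter), exchanges one large group for another on the same aromatic carbon and produces no movement beyond the scatter. Compound 3, carrying two trifluoromethyl groups on that ring, gives a number indistinguishable from the other two.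

The next compound, compound 4, `COc1cc(/C=C/C(C)=O)ccc1OCc1cn(-c2ccc(-c3ccccc3)cc2)nn1`, differs from compound 2 by phenyl in place of benzamido on an aromatic carbon. This is again a replacement at the same position, of a kind the series has so far tolerated without measurable effect. The step that bears on it, from compound 1 to compound 2, was flat. The expectation for compound 4 is therefore a step of a 1.1-fold lower number from compound 2 to compound 4 (0.02 log units; within the scatter), that is, no change beyond the scatter. Compound 4 is estimated at 82000 nM in this assay, with a range from 40000 nM to 170000 nM.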

Compound 4, half-maximal inhibitory concentration: 65400 nM
Compound 4: the middle estimate sits 1.3-fold (0.10 log units) above what was measured, and the stated range covers the measured number.
By their numbers in this assay, from the lowest: compounds 4, 1, 2 and 3 (each within the scatter of the next).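

The new result widens what this aromatic carbon tolerates. In this assay, benzamido gives way to phenyl with a 1.3-fold lower number from compound 2 to compound 4 (0.12 log units; within the scatter) and so phenyl, with 0 hydrogen-bond donors and 0 hydrogen-bond acceptors, cannot be told apart from benzamido, which carries 1 of each. Against the group of 8 heavy atoms, phenyl gives a 1.2-fold lower number from compound 1 to compound 4 (0.06 log units; within the scatter) and this extends the earlier flat step, which only exchanged one nitrogen-bearing group for another: here the entering group holds carbon alone, and still nothing moves beyond the scatter. No measurement on hand accounts for these numbers coinciding.

From the compounds shown here alone, all the groups at this site so far are large aromatic ones or, in compound 3, a pair of trifluoromethyl groups, so it remains open whether a small group such as an amine, a carboxylic acid or a plain hydrogen on this carbon would give a step beyond the scatter. Going by these compounds, it is also open whether changes to the shared core, rather than to this site, would shift the number at all.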